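A few compounds are considered here, and "the series" means these few. Any claim that something is new, unique, unknown or untested is made for them only; others in the source may bear on it.

Measured compounds:
Compound 1, `Cc1nc(Nc2cccc(Cl)c2)sc1C(=O)/C=C/c1ccc(Cl)cc1`: in a functional assay on Bel-7402 cells (Homo sapiens) for cytotoxicity, read by MTT assay (a higher number here means a weaker inhibitor, a lower number a stronger inhibitor), compound 1 gives > 25000 nM, which is a limit of the assay rather than a number.
Compound 2, `COc1cc(/C=C/C(=O)c2sc(Nc3ccc(C)cc3)nc2C)cc(OC)c1OC`: in this assay compound 2 gives > 25000 nM, again a limit rather than a number.
Compound 3, `COc1ccc(/C=C/C(=O)c2sc(Nc3ccc(Cl)cc3)nc2C)cc1`: in this assay compound 3 gives > 25000 nM, also a limit.

All three measured compounds share a core and differ in the groups on their two outer rings, yet none of them reaches a measurable number in this assay. Going by the values given here, compound 2 therefore stands nowhere in particular: its value is only a limit, and the other two values are limits as well, so no compound can be ranked against another here. The one thing the data show is the limit of > 25000 nM in this assay, at which 3 of the 3 values shown sit.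

The compound still to be measured is compound 4, `COc1cc(/C=C/C(=O)c2sc(Nc3ccc(Cl)cc3)nc2C)cc(OC)c1OC`. It differs from compound 2 in one place: chloro in place of methyl on an aromatic carbon. Its other outer ring is the same as in compound 2. Compound 3 carries the same (4-chlorophenyl)amino group as compound 4, and compound 3 also sits at the limit. With every measured value at the limit, no step beyond the scatter can be expected in either direction. The expected step that the limit leaves unreadable from compound 2 to compound 4 is essentially none. Compound 4 is therefore estimated at 30000 nM, with a range from 10000 nM to 100000 nM, and most likely the assay will again report only a limit.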

Compound 4, half-maximal inhibitory concentration: > 25000 nM
Compound 4: only a limit was reported; the forecaster's own chance of this, stated with the estimate: 80%; the middle value does not contradict the limit.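

Going by these compounds alone, compound 2 and compound 4 both sit at a limit rather than at a number, so the change from methyl to chloro gives no step that can be read. The compounds shown leave open how they rank against one another and whether any change on the outer rings would give a measurable value; what stands is one shared result: the limit of > 25000 nM in this assay, at which 4 of the 4 values shown sit.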